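A few compounds are considered here, and "the series" means these few. Any claim that something is new, unique, unknown or untested is made for them only; others in the source may bear on it.

Measured in a functional assay on A2780 cells (Homo sapiens) for antiproliferative activity, read by MTT assay, with a stated time of 48 h; a lower number here means a stronger inhibitor, a higher number a weaker inhibitor:
- compound 1 `C=C(c1ccc(OC)cc1NC(=O)CO)c1ccc(OC)c2c1OC(C)(C)C=C2`: 40 nM
- compound 2 `C=C(c1ccc(OC)cc1NC(=O)CNCC)c1ccc(OC)c2c1OC(C)(C)C=C2`: 1030 nM
- compound 3 `C=C(c1ccc(OC)cc1NC(=O)CN(C)C)c1ccc(OC)c2c1OC(C)(C)C=C2`: not yet measured

Compound 2, at 1030 nM, holds the higher of the two numbers in this assay. Within the data shown here, the one measured step, ethylamino in place of hydroxy on the same chain carbon, is a 26-fold higher number from compound 1 to compound 2 (1.41 log units; beyond the scatter). Compound 3 shares the core of compound 2 and differs as follows: dimethylamino in place of ethylamino on a saturated chain carbon bound to a carbonyl carbon. This places dimethylamino where ethylamino stood, on a saturated chain carbon bound to a carbonyl carbon. Among the measured compounds shown here, no measured step covers this exchange. The step to compound 2 shows only that this place can respond strongly, and it gives no direction for exchanging one amino group for the other. Only a small change, of uncertain direction, is therefore expected, and the margin stays wide. The expected change is a 1.3-fold lower number from compound 2 to compound 3 (0.11 log units; within the scatter). For compound 3 the estimated value is 800 nM, with an expected range from 250 nM to 2500 nM.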

Compound 3, half-maximal inhibitory concentration: 420 nM
Estimate against measurement, compound 3: 1.9-fold (0.28 log units) above; the measured number falls inside the stated range.
By their numbers in this assay, from the lowest: compound 1; then compound 3; then compound 2.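

In this assay, dimethylamino in place of ethylamino on a saturated chain carbon bound to a carbonyl carbon gives a 2.5-fold lower number from compound 2 to compound 3 (0.39 log units; beyond the scatter) and thus shows that this place distinguishes between two amino groups of equal heavy-atom count. The gain does not close the gap to the hydroxy compound, since dimethylamino in place of hydroxy still gives an 11-fold higher number from compound 1 to compound 3 (1.02 log units; beyond the scatter) and compound 1 keeps the lowest number of the three. Nothing at hand accounts for either step.

From the compounds shown here alone, it remains open whether the unsubstituted amine, a cyclic amine such as pyrrolidine or morpholine, or a longer chain would come closer to compound 1. Also open, going by these compounds, is whether a methoxy group at this place would keep the standing of hydroxy.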